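Compound 3 to compound 4: chloro to methyl

The source may hold more compounds than are shown below. What is called first, only, known or untested is meant among the compounds shown, and "the series" means these compounds.

In a functional assay on MDA-MB-231 cells (Homo sapiens) for antiproliferative activity, read by MTT assay, with a stated time of 72 h (a lower number here means a stronger inhibitor, a higher number a weaker inhibitor), compound 1 `CCNC(=O)CCc1cccc2c1B(O)OC2` gives > 100000 nM, which is a limit of the assay and not a number.

Compound 2 `O=C(CCc1cccc2c1B(O)OC2)NCc1ccccc1` gives > 100000 nM, also a limit of the assay.

Going by the values given here, compound 3 `O=C(CCc1cccc2c1B(O)OC2)Nc1ccc(Cl)cc1` gives 3600 nM, the only true number so far. The other two compounds sit at the same limit: the limit of > 100000 nM in this assay, at which 2 of the 3 values shown sit.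

The next compound is compound 4 `Cc1ccc(NC(=O)CCc2cccc3c2B(O)OC3)cc1`. The change is methyl in place of chloro on an aromatic carbon, para to a large group, so 4-chlorophenyl becomes 4-methylphenyl.

Among the compounds with values here, two measured steps bear on this, though only indirectly. They are an at least 27-fold lower number from compound 1 to compound 3 (1.44 log units; beyond the scatter) and an at least 27-fold lower number from compound 2 to compound 3 (1.44 log units; beyond the scatter), both large and both replacing the whole group on the amide nitrogen with 4-chlorophenyl. The step that the two limits leave unreadable from compound 1 to compound 2 cannot be read. Within the data shown here, no measured step varies only the group at the position that changes here, so the large steps set no size for this exchange. Compound 4 keeps the phenyl ring gained in those steps and exchanges one heavy atom, so no step beyond the scatter is expected in this assay.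

The expected step is a 1.4-fold higher number from compound 3 to compound 4 (0.14 log units; within the scatter).

For compound 4 the estimated value is 5000 nM, with an expected range of 1800 nM to 16000 nM.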

Compound 4, half-maximal inhibitory concentration: 1100 nM
For compound 4 the middle estimate is 4.5-fold (0.66 log units) above the measured one, outside the stated range (below it).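

In this assay methyl in place of chloro on an aromatic carbon, para to a large group, gives a 3.3-fold lower number from compound 3 to compound 4 (0.51 log units; beyond the scatter) and so shows that this position responds to the exchange of one heavy atom for another, although neither group carries a ring, a hydrogen-bond donor or acceptor, or a charge. The earlier compounds shown here differed only in the whole group on the amide nitrogen, whereas this pair shows that the substituent on the phenyl ring can itself move the value beyond the scatter. Against the ethyl and benzyl amides the 4-methylphenyl group gives an at least 90-fold lower number from compound 2 to compound 4 (1.95 log units; beyond the scatter) and also an at least 90-fold lower number from compound 1 to compound 4 (1.95 log units; beyond the scatter) as steps that rest on a limit of the assay and not on a number: the limit of > 100000 nM in this assay, at which 2 of the 4 values shown sit.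

Only chloro and methyl stand at this position among the compounds shown, so a methoxy or trifluoromethyl group in the same place remains an open test of how far the value can move. Also open, from the compounds shown here alone, is whether an unsubstituted phenyl ring, or a longer chain linking the shared core to the amide, would hold the value of compound 4 at 1100 nM in this assay or lose it.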